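Propargyl and allyl amides: whole-animal toxicity notes

This account rests on a few compounds, and the source may have more. Where it says the series, first, only, none or still open, it means among the compounds named here.

Measured so far:
Compound 1 `C#CCNC(=O)/C(C)=C(\C)c1ccc(Cl)cc1` gives 400 mg/kg.
Compound 2 `C#CCNC(=O)/C(C)=C(\C)c1ccccc1` gives 400 mg/kg.
Compound 3 `C=CCNC(=O)/C(C)=C(\C)c1ccc(Cl)cc1` gives 90 mg/kg.

All three numbers come from a toxicity assay on the whole organism (strain Icem-CET (SPF Caw)) for cytotoxicity, with Mus musculus as the target; a higher number here means that more compound is needed for the effect, a lower number that less compound is needed. Compound 4 `C=CCNC(=O)/C(C)=C(\C)c1ccccc1` has not yet been run in this assay. It differs from compound 3 by hydrogen in place of chloro on an aromatic carbon. The same change occurs once among the measured compounds, as hydrogen in place of chloro on an aromatic carbon, and there the result was no change at the digits printed from compound 1 to compound 2 (within the scatter). The two cores on which the change is made differ by vinyl in place of ethynyl on a saturated chain carbon bound to an amide-type nitrogen, a step that gave a 4.4-fold lower number from compound 1 to compound 3 (0.65 log units; beyond the scatter). The place of the chloro-to-hydrogen change is described identically on both cores, so it is taken as the same change. Because the measured instance gave no change at the digits printed from compound 1 to compound 2 (within the scatter), the step from compound 3 to compound 4 is expected to be no change at the digits printed from compound 3 to compound 4 (within the scatter), essentially flat. Compound 4 is therefore estimated at 90 mg/kg, with an expected range from 40 mg/kg to 200 mg/kg.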

Compound 4, dose for half-maximal effect: 300 mg/kg
Compound 4: middle estimate off by 3.3-fold (0.52 log units), on the low side; measured number above the stated range.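

In this assay, hydrogen in place of chloro gives a 3.3-fold higher number from compound 3 to compound 4 (0.52 log units; beyond the scatter), and vinyl in place of ethynyl on the core without the chloro gives a 1.3-fold lower number from compound 2 to compound 4 (0.12 log units; within the scatter). The chloro-to-hydrogen change does not carry over from the propargyl amide core to the allyl amide core: the same change on two cores in this assay, no change at the digits printed (within the scatter) from compound 1 to compound 2 and a 3.3-fold higher number (0.52 log units; beyond the scatter) from compound 3 to compound 4, 3.3-fold (0.52 log units) apart, beyond the scatter of two such steps The vinyl-for-ethynyl change fails to carry over in the same way, but this is the same gap seen from the other side and rests on only four compounds, so it gives neither a cause nor a rule for other cores: the same change on two cores in this assay, a 4.4-fold lower number (0.65 log units; beyond the scatter) from compound 1 to compound 3 and a 1.3-fold lower number (0.12 log units; within the scatter) from compound 2 to compound 4, 3.3-fold (0.52 log units) apart, beyond the scatter of two such steps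

Still open, from the compounds shown here alone, is whether a fluoro or methoxy group in place of the chloro would behave like compound 3 or like compound 4. The same question stands for a longer chain on the amide nitrogen.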